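The compounds below may be only part of what the source reports. "The series", "measured", "known", "first", "only" and "open" are said of these compounds alone.

Measured compounds:
Compound 1 `COC(=O)[C@@]1(C)CCC=C2[C@@H]1CC[C@@H](C)[C@]2(C)Cc1c[nH]c2ccc(Cl)cc12`: 16000 nM
Compound 2 `COC(=O)[C@@]1(C)CCC=C2[C@@H]1CC[C@@H](C)[C@]2(C)Cc1c(C)[nH]c2ccc(Cl)cc12`: 17000 nM
Compound 3 `COC(=O)[C@@]1(C)CC[C@@H]2C3=C1CC[C@@H](C)[C@]3(C)C[C@@H]1c3ccccc3N[C@H]21`: 39000 nM

All three were tested in a functional assay on A549 cells (Homo sapiens) for inhibition, read by sulforhodamine B assay, with a stated time of 48 h; a higher number here means a weaker inhibitor of growth, a lower number a stronger inhibitor of growth. Compound 1 gives 16000 nM and compound 2 gives 17000 nM, so the change methyl in place of hydrogen on an aromatic carbon leaves a step of a 1.1-fold higher number from compound 1 to compound 2 (0.03 log units; within the scatter). Compound 3 gives 39000 nM, the highest of the three numbers; how its core differs from that of compound 1 is not broken down here.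

Compound 4 `COC(=O)[C@@]1(C)CC[C@@H]2C3=C1CC[C@@H](C)[C@]3(C)C[C@@H]1c3cc(C)ccc3N[C@H]21` has not yet been measured. It differs from compound 3 by methyl in place of hydrogen on an aromatic carbon. Among the compounds with values here, this is the same kind of change as the one from compound 1 to compound 2, but the surroundings differ: there the methyl entered on a five-membered aromatic ring with one nitrogen, next to the ring nitrogen and next to the ring atom that bears a large group, whereas here it enters on a six-membered aromatic ring of carbon only, meta to a fused ring and para to a fused ring.

For compound 4 the expected step in this assay is a 1.0-fold higher number from compound 3 to compound 4 (0.01 log units; within the scatter). That expectation rests on the earlier step of a 1.1-fold higher number from compound 1 to compound 2 (0.03 log units; within the scatter), which stayed within the scatter. Compound 4 is therefore estimated at 40000 nM, with a range of 18000 nM to 85000 nM.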

Compound 4, concentration for 50% growth inhibition: 27000 nM
Compound 4: middle estimate off by 1.5-fold (0.17 log units), on the high side, within the range that was stated.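

In this assay, methyl in place of hydrogen on an aromatic carbon gives a 1.4-fold lower number from compound 3 to compound 4 (0.16 log units; within the scatter), so on this core the step stays within the scatter. Set beside the earlier case, the two steps cannot be told apart: the same change on two cores in this assay, a 1.1-fold higher number (0.03 log units; within the scatter) from compound 1 to compound 2 and a 1.4-fold lower number (0.16 log units; within the scatter) from compound 3 to compound 4, 1.5-fold (0.19 log units) apart, within the scatter of two such steps. Within the data shown here, in these two pairs, then, the change carried from one core to the other without a step that stands out from the scatter, but this rests on only two pairs, with the methyl on different kinds of aromatic ring, and it does not show that the methyl has any real effect on growth inhibition or that the same would hold on a further core.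

The compounds shown leave open whether a methoxy group or an amine on the same carbon of the six-membered aromatic ring would give a step beyond the scatter. They also leave open how a carboxylic acid in place of the methyl ester would read on either core.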